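A few compounds are considered here, and "the series" means these few. Any claim that something is new, unique, unknown or untested is made for them only; others in the source may bear on it.

In a functional assay on LoVo cells (Homo sapiens) for inhibition, read by MTT assay, with a stated time of 24 h (a lower number here means a stronger inhibitor, a higher number a weaker inhibitor), compound 3 (`CC1(C)[C@H]2CC[C@]1(C)N(Cc1cn(-c3ccccc3)nn1)C(=O)C2`) gives 50 nM. Compound 1 (`CC1(C)[C@H]2CC[C@]1(C)N(Cc1cn(-c3cccc(F)c3)nn1)C(=O)C2`) gives 90 nM and compound 2 (`CC1(C)[C@H]2CC[C@]1(C)N(Cc1cn(-c3ccc(C#N)cc3)nn1)C(=O)C2`) gives 90 nM, so compound 3 stands within the scatter of both. Compound 4 (`COc1cccc(-n2cc(CN3C(=O)C[C@@H]4CC[C@@]3(C)C4(C)C)nn2)c1`) carries methoxy in place of hydrogen on an aromatic carbon, meta to a large group: methoxy in place of hydrogen on an aromatic carbon. Two measured steps exchange a substituent for hydrogen on an aromatic carbon: a 1.8-fold lower number from compound 1 to compound 3 (0.26 log units; within the scatter) with fluoro leaving, and a 1.8-fold lower number from compound 2 to compound 3 (0.26 log units; within the scatter) with cyano leaving. Both stay within the scatter, but neither involves methoxy. On that evidence, the step of a 1.4-fold higher number from compound 3 to compound 4 (0.15 log units; within the scatter) is expected to stay within the scatter. For compound 4 the estimated value is 70 nM, with an expected range of 30 nM to 180 nM.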

Compound 4, half-maximal inhibitory concentration: 80 nM
Compound 4: the middle estimate sits 1.1-fold (0.06 log units) below what was measured; measured number inside the range.
By their numbers in this assay, from the lowest: compounds 3, 4, 1 and 2 (each within the scatter of the next).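

In this assay, methoxy at this place on the ring stays close to hydrogen, with a 1.6-fold higher number from compound 3 to compound 4 (0.20 log units; within the scatter), and close to fluoro, with a 1.1-fold lower number from compound 1 to compound 4 (0.05 log units; within the scatter). The whole 3-methoxyphenyl group likewise stays close to 4-cyanophenyl, with a 1.1-fold lower number from compound 2 to compound 4 (0.05 log units; within the scatter), so an oxygen-linked substituent separates from none of the three earlier compounds. Nothing available explains these small steps. On these data alone, it remains open whether an amine or a carboxylic acid on this ring would also stay within the scatter, and whether methoxy would behave alike elsewhere on the ring.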